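Moving the Nitro Group on a Bis-arylidene Ketone

A few compounds are considered here, and "the series" means these few. Any claim that something is new, unique, unknown or untested is made for them only; others in the source may bear on it.

Compound 1 `COc1cc(/C=C2\CCC/C(=C\c3ccccc3[N+](=O)[O-])C2=O)cc(OC)c1OC` holds the lower of the two measured numbers in a functional assay on L1210 cells (Mus musculus) for cytotoxicity, with a stated time of 48 h (a higher number here means a weaker inhibitor, a lower number a stronger inhibitor), where compound 1 gives 1520 nM. Compound 2 `Cc1ccc(/C=C2\CCC/C(=C\c3cccc([N+](=O)[O-])c3)C2=O)cc1` gives 41800 nM in this assay, a gap beyond the scatter. Compound 3 `COc1cc(/C=C2\CCC/C(=C\c3cccc([N+](=O)[O-])c3)C2=O)cc(OC)c1OC` differs from compound 1 by 3-nitrophenyl in place of 2-nitrophenyl on a double-bonded chain carbon bound to a double-bonded ring carbon. For the measured compounds named here, no measured pair isolates this change, since compound 2 also carries a different ring on its other arm. A modest step toward a higher number is expected, a 2.6-fold higher number from compound 1 to compound 3 (0.42 log units; beyond the scatter). Compound 3 is therefore estimated at 4000 nM, within a range from 1000 nM to 15000 nM.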

Compound 3, half-maximal inhibitory concentration: 42200 nM
Compound 3: middle estimate off by 11-fold (1.02 log units), on the low side; measured number outside the range, above it.
By their numbers in this assay, from the lowest: compound 1; then compounds 2 and 3 (each within the scatter of the next).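

In this assay the placement of the nitro group alone carries a large step: 3-nitrophenyl in place of 2-nitrophenyl gives a 28-fold higher number from compound 1 to compound 3 (1.44 log units; beyond the scatter) with the same atoms joined differently. Compound 3 and compound 2, which share the 3-nitrophenyl, stand within the scatter of each other. No evidence at hand explains the step. Still open, on these data alone, is whether 2-nitrophenyl would give a similar step on the other arm of compound 2, and what a phenyl carrying an amine or a carboxylic acid would give at this place.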